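The source may report more compounds than this note shows. Statements on the series, on what has been measured and on what is new or still open speak of the compounds shown alone.

Measured compounds:
compound 1, `C=CCn1c(=O)c2[nH]cnc2n(CCC)c1=O` — 1700 nM
compound 2, `CCCn1c(=O)n(CCC#N)c(=O)c2[nH]cnc21` — 15900 nM
compound 3, `CCCn1c(=O)n(CCCN(C)C)c(=O)c2[nH]cnc21` — 43200 nM

In an assay on Cerebral cortex for binding affinity to adenosine receptor A1 (Cavia porcellus), read by radioligand binding (a lower number here means a stronger inhibitor, a higher number a weaker inhibitor), compound 3 stands highest of the three, with compound 2 nearest to it and compound 1 furthest, both steps lying beyond the scatter: a 2.7-fold higher number from compound 2 to compound 3 (0.43 log units; beyond the scatter) and a 25-fold higher number from compound 1 to compound 3 (1.41 log units; beyond the scatter). Compound 4, `CCCn1c(=O)n(CCOC)c(=O)c2[nH]cnc21`, differs from compound 3 in one place: methoxy in place of (dimethylamino)methyl on a saturated chain carbon, two bonds along the chain from an aromatic nitrogen. For the measured compounds named here, the step that bears most directly on this change is the one from compound 2 to compound 3, which swaps a nitrile for a (dimethylamino)methyl on the same chain carbon and gives a 2.7-fold higher number from compound 2 to compound 3 (0.43 log units; beyond the scatter). The nitrile of compound 2 and the methoxy entering in compound 4 each bring one hydrogen-bond acceptor and no donor, so the reversal of that step offers the closest guide; compound 1, with its vinyl, shows that a small neutral chain end on this core can reach 1700 nM. Compound 4 is therefore expected to give a lower number in this assay than compound 3, estimated at a 4.8-fold lower number from compound 3 to compound 4 (0.68 log units; beyond the scatter). The estimate for compound 4 is 9000 nM, with a range from 2500 nM to 30000 nM.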

Compound 4, inhibition constant: 2500 nM
Compound 4: the middle estimate sits 3.6-fold (0.56 log units) above what was measured, and the stated range covers the measured number.
By their numbers in this assay, from the lowest: compounds 1 and 4 (each within the scatter of the next); then compound 2; then compound 3.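

In this assay, the end of this chain has a strong influence: methoxy in place of (dimethylamino)methyl gives a 17-fold lower number from compound 3 to compound 4 (1.24 log units; beyond the scatter) even though the two groups have the same counts of hydrogen-bond donors and acceptors and neither carries a net charge. Those counts therefore do not separate the two compounds, and the gain in affinity is not limited to removing the (dimethylamino)methyl group. Methoxy in place of the nitrile gives a 6.4-fold lower number from compound 2 to compound 4 (0.80 log units; beyond the scatter) as well, while methoxymethyl in place of vinyl gives a 1.5-fold higher number from compound 1 to compound 4 (0.17 log units; within the scatter) and so leaves compound 4 level with compound 1.

The compounds shown leave open how a hydroxyl group, a primary amine or a longer ether chain at this end would compare with methoxy. No evidence is available to explain these differences.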